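The compounds below may be only part of what the source reports. "The series", "measured", "known", "first", "only" and "open" are said of these compounds alone.

Compound 3 `O=c1c2ccccc2[se]n1-c1nc(SCc2ccc(F)cc2)n[nH]1` carries a 4-fluorophenyl on a saturated chain carbon bound to a sulfur. In a functional assay on A549 cells (Homo sapiens) for antiproliferative activity, read by CCK-8 assay, with a stated time of 48 h (on this read-out lower numbers stand for stronger inhibition and higher numbers for weaker inhibition), compound 3 gives 36400 nM, the larger of the two plain numbers obtained here. Compound 1 `CCCCCCSc1n[nH]c(-n2[se]c3ccccc3c2=O)n1` gives 20300 nM, and the step from compound 1 to compound 3 is a 1.8-fold higher number from compound 1 to compound 3 (0.25 log units; within the scatter), so the two sit close together. Compound 2 `Cc1ccc(CSc2n[nH]c(-n3[se]c4ccccc4c3=O)n2)cc1` reaches only > 50000 nM, which is a limit of this assay rather than a number (the limit of > 50000 nM in this assay, at which 1 of the 3 values shown sits). From compound 1 to compound 2 the step is an at least 2.4-fold higher number from compound 1 to compound 2 (0.39 log units; beyond the scatter). Compound 4 `CCCCCSc1n[nH]c(-n2[se]c3ccccc3c2=O)n1` is the member not yet measured, and it differs from compound 3 in one place: butyl in place of 4-fluorophenyl on a saturated chain carbon bound to a sulfur. This change largely undoes the step from compound 1 to compound 3, which stayed within the scatter, except that the butyl entering is shorter than the pentyl of compound 1. A small move to a lower number, or none beyond the scatter, is therefore expected, namely a 1.5-fold lower number from compound 3 to compound 4 (0.16 log units; within the scatter). Compound 4 is estimated at 25000 nM, with a range from 10000 nM to 60000 nM.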

Compound 4, half-maximal inhibitory concentration: 21100 nM
Compound 4: middle estimate off by 1.2-fold (0.07 log units), on the high side; the range from low to high includes it.
By their numbers in this assay, from the lowest: compounds 1, 4 and 3 (each within the scatter of the next). At a limit, above all of these: compound 2.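

At this position, in this assay, the exchange of an aromatic group for a plain chain gives a 1.7-fold lower number from compound 3 to compound 4 (0.24 log units; within the scatter), while trimming the end of the chain gives a 1.0-fold higher number from compound 1 to compound 4 (0.02 log units; within the scatter), so neither change moves the number beyond the scatter. Compound 2 does stand apart, with an at least 2.3-fold lower number from compound 2 to compound 4 (0.37 log units; beyond the scatter), but compound 3 also carries an aromatic ring and goes against any rule that chains outperform rings. Compound 2 sits at a limit of the assay rather than at a number: the limit of > 50000 nM in this assay, at which 1 of the 4 values shown sits.

As far as these compounds go, whether a chain longer than pentyl would move the number beyond the scatter remains open. So does the effect of an amine or a carboxylic acid at the end of the chain.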